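A Phenylethyl Group Replaces the Fluorophenyl of Compound 3

This account rests on a few compounds, and the source may have more. Where it says the series, first, only, none or still open, it means among the compounds named here.

Three measured compounds share one core and differ only in the halogen on the outer aromatic ring: compound 1 `CCCn1c(=O)[nH]c2nc(-c3ccc(S(=O)(=O)N4CCN(c5cccc(Cl)c5)CC4)cc3)[nH]c2c1=O`, compound 2 `CCCn1c(=O)[nH]c2nc(-c3ccc(S(=O)(=O)N4CCN(c5cccc(Br)c5)CC4)cc3)[nH]c2c1=O` and compound 3 `CCCn1c(=O)[nH]c2nc(-c3ccc(S(=O)(=O)N4CCN(c5cccc(F)c5)CC4)cc3)[nH]c2c1=O`. In an assay on CHO cells for displacement of a labelled ligand from adenosine receptor A3 (Homo sapiens), read by scintillation counting, with a stated time of 45 min, in the presence of a further agent that is not named here (on this read-out higher numbers stand for weaker inhibition and lower numbers for stronger inhibition), compound 1 gives 53.5 nM. Compound 2 reaches only a limit of the assay, > 1000 nM. Compound 3 likewise gives only a limit, > 1000 nM. Compound 3 thus stands at the weak edge of what has been seen, with one other value also sitting at that limit. Among the measured compounds shown here, the steps of an at least 18-fold higher number from compound 1 to compound 2 (1.27 log units; beyond the scatter) and an at least 18-fold higher number from compound 1 to compound 3 (1.27 log units; beyond the scatter) both run from the single numbered value to the limit, while the step that the two limits leave unreadable from compound 2 to compound 3 stays unreadable because of the limit of > 1000 nM in this assay, at which 2 of the 3 values shown sit.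

Compound 4, `CCCn1c(=O)[nH]c2nc(-c3ccc(S(=O)(=O)N4CCN(C(C)c5ccccc5)CC4)cc3)[nH]c2c1=O`, arises from compound 3 through the change (1-phenylethyl in place of 3-fluorophenyl on an amine nitrogen in a ring). For the measured compounds named here, none of the measured steps bears directly on this: each of them swaps one halogen for another on the outer ring, whereas here the whole group on the ring nitrogen is exchanged for one of a different kind. The measured steps therefore give no direction, and the starting point is only a limit. Compound 4 is expected to come out near 500 nM, somewhere between 50 nM and 5000 nM. The step of an at least 2.0-fold lower number from compound 3 to compound 4 (0.30 log units; that floor lies within the scatter) is the estimated consequence.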

Compound 4, inhibition constant: > 1000 nM
Compound 4: no number, only a limit; the forecaster's own chance of this, stated with the estimate: 45%; middle value at least 2.0-fold (0.30 log units) from the limit.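

Until now, only halogen swaps on the outer ring had been seen; compound 4 shows that exchanging the whole group on the ring nitrogen also fails to match compound 1. In this assay, among the compounds shown here, the one readable step is an at least 18-fold higher number from compound 1 to compound 4 (1.27 log units; beyond the scatter), with 1-phenylethyl in place of 3-chlorophenyl, even though both groups carry one six-membered aromatic ring of carbon only and compound 4 has no halogen at all. Among the compounds shown, 3-chlorophenyl alone gives a numbered value, while the steps from compound 2 and from compound 3 to compound 4 cannot be read because each pair has a limit at both ends: the limit of > 1000 nM in this assay, at which 3 of the 4 values shown sit.

On these data alone, whether compound 4 is stronger or weaker than compound 2 or compound 3 therefore stays open, since all three sit at a limit of the assay. Also open, as far as these compounds go, is how a benzyl group or a 3-methylphenyl group would behave on the same ring nitrogen, and whether either could come close to the value of compound 1.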